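A few compounds are considered here, and "the series" means these few. Any claim that something is new, unique, unknown or untested is made for them only; others in the source may bear on it.

Measured compounds:
- Compound 1 `Cc1cnc(Nc2ccc([N+](=O)[O-])cc2)nc1Nc1nc2ccccc2s1`: > 50000 nM in a functional assay on PC-3 cells (Homo sapiens) for antiproliferative activity, read by MTT assay, with a stated time of 48 h (on this read-out lower numbers stand for stronger inhibition and higher numbers for weaker inhibition), a limit of the assay.
- Compound 2 `COc1cccc(Nc2ncc(C)c(Nc3nc4ccccc4s3)n2)c1`: > 50000 nM in this assay, a limit.
- Compound 3 `Cc1cnc(Nc2cccc(F)c2)nc1Nc1nc2ccccc2s1`: > 50000 nM in this assay, a limit.

Compound 1 stands at the limit, and every value shown sits there (the limit of > 50000 nM in this assay, at which 3 of the 3 values shown sit). The steps a step that the two limits leave unreadable from compound 1 to compound 2, a step that the two limits leave unreadable from compound 1 to compound 3 and a step that the two limits leave unreadable from compound 2 to compound 3 are therefore unreadable in size and direction. Compound 4 `Cc1cnc(Nc2ccc(N3CCCCC3)cc2)nc1Nc1nc2ccccc2s1` differs from compound 1 by piperidin-1-yl in place of nitro on an aromatic carbon. For the measured compounds named here, no measured step touches this change, and the measured steps give no direction. Compound 4 is expected to stay near the limit, estimated at 40000 nM with a range from 8000 nM to 200000 nM. The step of an at least 1.2-fold lower number from compound 1 to compound 4 (0.09 log units; that floor lies within the scatter) is thus expected to be within the scatter, with a real chance that only a limit is reported.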

Compound 4, half-maximal inhibitory concentration: > 50000 nM
Compound 4: no number, only a limit (the forecaster's own chance of this, stated with the estimate: 65%); at least 1.2-fold (0.09 log units) between middle value and limit.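

The step from compound 1 to compound 4 cannot be read, nor can any step among compound 1, compound 2, compound 3 and compound 4, as all stay at a limit: the limit of > 50000 nM in this assay, at which 4 of the 4 values shown sit.

Still open, from the compounds shown here alone, is whether any change on the shared core gives a measurable number.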